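A few compounds are considered here, and "the series" means these few. Any claim that something is new, unique, unknown or untested is made for them only; others in the source may bear on it.

Measured in an ADME assay on MT4 cells (Homo sapiens) for cytotoxicity, read by MTT assay, with a stated time of 5 days; on this read-out higher numbers stand for lower toxicity in this test and lower numbers for higher toxicity in this test:
compound 1 `COc1cc2nc([S+]([O-])CC(=O)Nc3cccc(F)c3)nc(Nc3c(Cl)cc(/C=C/C#N)cc3Cl)c2cc1OC`: 9550 nM
compound 2 `COc1cc2nc([S+]([O-])CC(=O)Nc3ccc(C(F)(F)F)cc3)nc(Nc3c(Cl)cc(/C=C/C#N)cc3Cl)c2cc1OC`: 22000 nM
compound 3 `COc1cc2nc([S+]([O-])CC(=O)Nc3cccc(C#N)c3)nc(Nc3c(Cl)cc(/C=C/C#N)cc3Cl)c2cc1OC`: >= 70300 nM

Compound 3 stands at the high end of this short series, but its >= 70300 nM is a limit of the assay and not a number.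

Compound 4 `COc1cc2nc([S+]([O-])CC(=O)Nc3cc([N+](=O)[O-])ccc3F)nc(Nc3c(Cl)cc(/C=C/C#N)cc3Cl)c2cc1OC` keeps the shared core and carries 2-fluoro-5-nitrophenyl in place of 3-cyanophenyl on an amide-type nitrogen.

Within the data shown here, three measured steps bear on that place: a 2.3-fold higher number from compound 1 to compound 2 (0.36 log units; beyond the scatter), an at least 3.1-fold higher number from compound 2 to compound 3 (0.50 log units; beyond the scatter) and an at least 7.3-fold higher number from compound 1 to compound 3 (0.86 log units; beyond the scatter). All three lie beyond the scatter, and the two that end at the limit are the largest evidence that this group matters in this assay. Among the measured compounds shown here, no measured compound carries a nitro group, so the size of the step can only be judged from this spread. A lower number is expected, moving back towards the values of the other two compounds, though another limit remains possible.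

The expected change is an at least 3.1-fold lower number from compound 3 to compound 4 (0.50 log units; beyond the scatter). For compound 4 the estimate is 22000 nM, with an expected range from 7000 nM to 70000 nM.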

Compound 4, half-maximal cytotoxic concentration: > 194000 nM
Compound 4 was reported as a limit (the forecaster's own chance of this, stated with the estimate: 20%); middle value at least 8.8-fold (0.94 log units) away from the limit.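

In this assay, compound 4 gives a limit of the assay and not a number, the second such result at this place on the amide-type nitrogen: the limit of > 194000 nM in this assay, at which 1 of the 4 values shown sits.

Among these compounds, replacing the groups of the two compounds with numerical values, 2-fluoro-5-nitrophenyl gives an at least 8.8-fold higher number from compound 2 to compound 4 (0.94 log units; beyond the scatter) and an at least 20-fold higher number from compound 1 to compound 4 (1.30 log units; beyond the scatter), so 3-cyanophenyl is no longer the only group here that sets a compound clearly apart from compounds 1 and 2. The step from compound 3 to compound 4 cannot be read, and the two groups cannot be put in order.

As far as these compounds go, the nitro and fluoro groups enter together in compound 4, so their separate shares in this result remain open. Also open, from the compounds shown here alone, is how a phenyl group carrying an amine or a carboxylic acid would read in this assay.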